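Three Limits and a Fourth Compound to Be Placed

The compounds below may be only part of what the source reports. "The series", "measured", "known", "first", "only" and "open" are said of these compounds alone.

Compound 1 `C/N=C(/NC#N)NCCCn1nc(-c2ccccc2)ccc1=O`: in a functional assay on the whole organism (stomach) with Rattus norvegicus as the target (on this read-out higher numbers stand for an effect only at larger amounts of compound and lower numbers for an effect already at smaller amounts), compound 1 gives only the limit > 100 mg/kg.
Compound 2 `C/N=C(/NC#N)NCCCCn1nc(N(C)C)ccc1=O`: in this assay compound 2 gives only the limit > 100 mg/kg.
Compound 3 `CC(C)(C)/N=C(\S)NCCCCn1nc(-c2ccccc2)ccc1=O`: in this assay compound 3 gives only the limit > 100 mg/kg.

Compound 2 therefore stands at a limit of the measurement, not at a number, and every value here does the same (the limit of > 100 mg/kg in this assay, at which 3 of the 3 values shown sit). Compound 4 `C/N=C(/NC#N)NCCCCn1nc(-c2ccc(C)cc2)ccc1=O` differs from compound 2 by 4-methylphenyl in place of dimethylamino on an aromatic carbon. Going by the values given here, no step between two measured compounds exists, so no direction can be read off. The expected step of a number no higher from compound 2 to compound 4 (the limit leaves the size open) is therefore none beyond the scatter. For compound 4 the estimate in this assay is 100 mg/kg, from 30 mg/kg to 300 mg/kg, and most probably only a limit will again be reported.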

Compound 4, dose for half-maximal effect: > 100 mg/kg
Compound 4 ended at the assay's limit; the forecaster's own chance of this, stated with the estimate: 70%; the middle value sits exactly at the limit.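

Going by these compounds alone, compound 2 and compound 4 both stop at a limit, so no step between them can be read: the limit of > 100 mg/kg in this assay, at which 4 of the 4 values shown sit.

In this assay the compounds shown leave open which change to the shared core, if any, would give a measured number instead of a limit.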